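The source may hold more compounds than are shown below. What is called first, only, known or untested is meant among the compounds shown, and "the series" means these compounds.

Measured compounds in a physicochemical assay for solubility, read by HPLC, in phosphate buffer, with a stated time of 24 h, at pH 7.4, tested at 100 uM; a higher number here means a more soluble compound, a lower number a less soluble compound:
compound 1, `COc1ccc(Nc2c(NCCCCCC(=O)NO)c(=O)c2=O)cc1`: 3300000 nM
compound 2, `O=C(CCCCCNc1c(Nc2ccc(C(F)(F)F)cc2)c(=O)c1=O)NO`: 4500000 nM
compound 3, `CC(C)(CCCCC(=O)NO)Nc1c(Nc2ccc(C(F)(F)F)cc2)c(=O)c1=O`: 36000000 nM

Compound 2 and compound 1 differ in one place, (methoxy in place of trifluoromethyl on an aromatic carbon), and this change gives a 1.4-fold lower number from compound 2 to compound 1 (0.13 log units; within the scatter), so the two values cannot be told apart. Compound 3 stands highest of the three in this assay; the difference between its core and the core of compound 2 is not broken down here, and the two values simply show compound 3 well above compound 2 and compound 1.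

Compound 4, `COc1ccc(Nc2c(NC(C)(C)CCCCC(=O)NO)c(=O)c2=O)cc1`, has not yet been measured. It differs from compound 3 by methoxy in place of trifluoromethyl on an aromatic carbon, the same change as that from compound 2 to compound 1. Because that earlier change gave a 1.4-fold lower number from compound 2 to compound 1 (0.13 log units; within the scatter), compound 4 is expected to stay close to compound 3, with an estimated step of a 1.2-fold lower number from compound 3 to compound 4 (0.08 log units; within the scatter). The estimate for compound 4 in this assay is 30000000 nM, expected to lie between 12000000 nM and 70000000 nM, resting on a single earlier pair, so it is held loosely.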

Compound 4, solubility: 99000000 nM
The estimate for compound 4 lay 3.3-fold (0.52 log units) below the measured number, and the stated range ends below it.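

In this assay, methoxy in place of trifluoromethyl on an aromatic carbon gives a 2.8-fold higher number from compound 3 to compound 4 (0.44 log units; beyond the scatter), whereas the same change on the other core gives a 1.4-fold lower number from compound 2 to compound 1 (0.13 log units; within the scatter). Among the compounds shown here, the change therefore does not carry from one core to the other as a fixed step: only the step on the core of compound 3 stands beyond the scatter, and the pair on the other core shows no readable difference. For the compounds shown here, these two pairs show only that the step was not the same on these two cores, not how it would behave on any other core, and nothing available here bears on why the pairs disagree.

On these data alone, what a nitrile, a chlorine atom or an amine would give on that same aromatic carbon remains open. Also open, as far as these compounds go, is whether a longer chain or a carboxylic acid in place of the hydroxamic acid chain would change how methoxy and trifluoromethyl compare in this assay.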